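The source may report more compounds than this note shows. Statements on the series, on what has been measured and on what is new or still open speak of the compounds shown alone.

Compound 3 `CCCCCCCCc1ccc(OCC(=O)Cn2nnc(-c3ccccn3)n2)cc1` is one of three compounds tested in an assay on microsomes from brain for inhibition of Fatty-acid amide hydrolase 1 (Rattus norvegicus), read by fluorescence and HPLC, with a stated time of 60 min (on this read-out lower numbers stand for stronger inhibition and higher numbers for weaker inhibition), where compound 3 gives 18 nM. Compound 1 `CCCCCCCCc1ccc(OCC(=O)Cn2nnc(SC)n2)cc1` gives 31 nM and compound 2 `CCCCCCCCc1ccc(OCC(=O)Cn2nnc(-c3ccccc3)n2)cc1` gives 24 nM; the differences, a 1.7-fold lower number from compound 1 to compound 3 (0.24 log units; within the scatter) and a 1.3-fold lower number from compound 2 to compound 3 (0.12 log units; within the scatter), do not separate these three compounds. Compound 4 `CCCCCCCCc1ccc(OCC(=O)Cn2nnc(CCC(=O)O)n2)cc1` differs from compound 3 in one place: 2-carboxyethyl in place of pyridin-2-yl on an aromatic carbon. Going by the values given here, the measured steps only ever swapped methylsulfanyl, phenyl and pyridin-2-yl at this position, and each stayed within the scatter; no measured step exchanges a ring for a 2-carboxyethyl chain. Compound 4 is therefore expected to remain in a similar region, with the step of a 2.8-fold higher number from compound 3 to compound 4 (0.44 log units; beyond the scatter) treated as uncertain. The estimate for compound 4 is 50 nM, within 12 nM to 250 nM.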

Compound 4, half-maximal inhibitory concentration: 30 nM
The estimate for compound 4 lay 1.7-fold (0.22 log units) above the measured number, and the stated range covers the measured number.
By their numbers in this assay, from the lowest: compounds 3, 2, 4 and 1 (each within the scatter of the next).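

Going by these compounds alone, compound 4 is the first here to carry a chain without a ring on this aromatic carbon, yet in this assay the steps of a 1.7-fold higher number from compound 3 to compound 4 (0.22 log units; within the scatter), a 1.3-fold higher number from compound 2 to compound 4 (0.10 log units; within the scatter) and a 1.0-fold lower number from compound 1 to compound 4 (0.01 log units; within the scatter) do not separate it from the others. Among these four compounds, then, this position takes 2-carboxyethyl, with its hydrogen-bond donor, as readily as the two rings or methylsulfanyl. Nothing given here explains why these different groups read alike. Going by these compounds, whether an amine or a much longer chain at this position would stay in the same range remains open.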